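The source may hold more compounds than are shown below. What is called first, only, known or untested is meant among the compounds shown, and "the series" means these compounds.

Measured compounds in an assay on isolated protein for inhibition of Amine oxidase [flavin-containing] B (Bos taurus); a higher number here means a weaker inhibitor, a lower number a stronger inhibitor:

Compound 1, `CCC(=O)N1N=C(c2ccc(Cl)cc2)CC1c1ccc(Cl)cc1`, gives 10000 nM.
Compound 2, `CCC(=O)N1N=C(c2ccc(F)cc2)CC1c1ccc(Cl)cc1`, gives 6310 nM.
Compound 3, `CCC(=O)N1N=C(c2ccc(OC)cc2)CC1c1ccc(Cl)cc1`, gives 851 nM.

Compound 1 and compound 2 differ by fluoro in place of chloro on an aromatic carbon, and that step reads a 1.6-fold lower number from compound 1 to compound 2 (0.20 log units; within the scatter). Compound 3 stands apart from compound 1 by methoxy in place of chloro on an aromatic carbon, the step being a 12-fold lower number from compound 1 to compound 3 (1.07 log units; beyond the scatter), and from compound 2 by a 7.4-fold lower number from compound 2 to compound 3 (0.87 log units; beyond the scatter).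

Compound 4, `CCC(=O)N1N=C(c2ccc(OC)cc2)CC1c1ccc(F)cc1`, is not yet measured. It differs from compound 3 by fluoro in place of chloro on an aromatic carbon, the same change that took compound 1 to compound 2, at a place described in the same words. Given that the earlier step was a 1.6-fold lower number from compound 1 to compound 2 (0.20 log units; within the scatter), the step from compound 3 to compound 4 is expected to be small, about a 1.4-fold lower number from compound 3 to compound 4 (0.15 log units; within the scatter), resting on that single pair alone. Compound 4 is therefore estimated at 600 nM, within 250 nM to 1800 nM.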

Compound 4, half-maximal inhibitory concentration: 100000 nM
The estimate for compound 4 lay 170-fold (2.22 log units) below the measured number, and the stated range ends below it.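

In this assay, the step of a 120-fold higher number from compound 3 to compound 4 (2.07 log units; beyond the scatter) is large, and fluoro in place of chloro on an aromatic carbon does not carry over unchanged from one core to another in this series: the same change on two cores in this assay, a 1.6-fold lower number (0.20 log units; within the scatter) from compound 1 to compound 2 and a 120-fold higher number (2.07 log units; beyond the scatter) from compound 3 to compound 4, 190-fold (2.27 log units) apart, beyond the scatter of two such steps
Among these compounds, the chloro replaced in compound 3 is not the same chloro as the one replaced in compound 1, so the two pairs differ in the site of the change as well as in the surrounding groups. These two pairs show that the outcome depends on the setting of the change, but not which feature of that setting decides it.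

Still open, on these data alone, is how bromo, methyl or an amine would read in place of the chloro that leaves compound 3. Also open, as far as these compounds go, is whether a longer alkoxy chain in place of methoxy would preserve the number of compound 3.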